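Anilide to aminoalkyl amide on the shared core

The source may hold more compounds than are shown below. What is called first, only, known or untested is meant among the compounds shown, and "the series" means these compounds.

Three anilides share the core seen in compound 1 `O=C(CCC(=O)OCCCCCCSc1ccc([N+](=O)[O-])c2nonc12)Nc1ccccc1F`, which in an assay on isolated protein for inhibition of glutathione S-transferase P (Homo sapiens), with a stated time of 10 min (on this read-out lower numbers stand for stronger inhibition and higher numbers for weaker inhibition), gives 9890 nM, the highest of the three numbers. Compound 2 `O=C(CCC(=O)OCCCCCCSc1ccc([N+](=O)[O-])c2nonc12)Nc1ccc(F)cc1` gives 8570 nM and compound 3 `Cc1ccc(NC(=O)CCC(=O)OCCCCCCSc2ccc([N+](=O)[O-])c3nonc23)cc1` gives 6800 nM. The steps of a 1.2-fold lower number from compound 1 to compound 2 (0.06 log units; within the scatter) and a 1.5-fold lower number from compound 1 to compound 3 (0.16 log units; within the scatter) both sit within the scatter, as does a 1.3-fold lower number from compound 2 to compound 3 (0.10 log units; within the scatter). Compound 4 `CCN(CC)CCCNC(=O)CCC(=O)OCCCCCCSc1ccc([N+](=O)[O-])c2nonc12` differs from compound 1 in that (3-(diethylamino)propyl in place of 2-fluorophenyl on an amide-type nitrogen). The measured steps only exchange one aromatic ring for another at this nitrogen; none replaces the ring with a chain, so they bear on this step only loosely and give no direction. The expected step is therefore a 1.0-fold higher number from compound 1 to compound 4 (0.00 log units; within the scatter), and compound 4 is estimated at 10000 nM, within 3000 nM to 35000 nM.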

Compound 4, half-maximal inhibitory concentration: 9550 nM
Estimate against measurement, compound 4: 1.0-fold (0.02 log units) above; the range from low to high includes it.
By their numbers in this assay, from the lowest: compounds 3, 2, 4 and 1 (each within the scatter of the next).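

At the amide-type nitrogen, 3-(diethylamino)propyl, which carries no ring, stands level with all three aromatic groups in this assay: a 1.0-fold lower number from compound 1 to compound 4 (0.02 log units; within the scatter), a 1.1-fold higher number from compound 2 to compound 4 (0.05 log units; within the scatter) and a 1.4-fold higher number from compound 3 to compound 4 (0.15 log units; within the scatter), each within the scatter. Among the compounds shown, then, an aromatic ring on this nitrogen is not needed for a number in this range, and exchanging ring for chain opens no measurable gap.

Open, going by these compounds, is whether a longer chain, a primary amine or a carboxylic acid at the chain end would give a step beyond the scatter. No measurement on hand accounts for the level values.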